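Esterifying the Phenol: Expected Effect of a Benzoyl Group

A few compounds are considered here, and "the series" means these few. Any claim that something is new, unique, unknown or untested is made for them only; others in the source may bear on it.

Measured compounds:
Compound 1, `CCCCCCC(=O)Oc1ccccc1-c1cc2ccccc2[nH]1`: 38000 nM
Compound 2, `Oc1ccccc1-c1cc2ccccc2[nH]1`: 130000 nM

Both compounds were tested in a functional assay on U-251 cells (Homo sapiens) for antiproliferative activity, read by sulforhodamine B assay, with a stated time of 72 h; a higher number here means that more compound is needed for the effect, a lower number that less compound is needed. Among the measured compounds shown here, compound 2, the free phenol, gives the highest of the two numbers; the only other compound, compound 1, sits a modest distance below it. For the measured compounds named here, the single measured step, a 3.4-fold higher number from compound 1 to compound 2 (0.53 log units; beyond the scatter), corresponds to hydrogen in place of hexylcarbonyl on the oxygen of the aromatic ring, so removing that ester raised the number.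

Compound 3, `O=C(Oc1ccccc1-c1cc2ccccc2[nH]1)c1ccccc1`, has not yet been measured. It differs from compound 2 by benzoyl in place of hydrogen on an oxygen on an aromatic ring. This is again an ester at the same oxygen, so the measured step bears on it directly, but run in the opposite direction: compound 1 shows that placing an acyl group there gave a lower number than compound 2. A similar modest drop is therefore expected, although the aromatic benzoyl group is not the same as the chain in compound 1, which leaves the exact size uncertain.

Compound 3 is thus expected to give about 45000 nM in this assay, within a range of 15000 nM to 130000 nM. That estimate amounts to an expected step of a 2.9-fold lower number from compound 2 to compound 3 (0.46 log units; beyond the scatter).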

Compound 3, half-maximal effective concentration: 39000 nM
For compound 3 the middle estimate is 1.2-fold (0.06 log units) above the measured one; the range from low to high includes it.
By their numbers in this assay, from the lowest: compounds 1 and 3 (each within the scatter of the next); then compound 2.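

In this assay the benzoyl ester gives a 3.3-fold lower number from compound 2 to compound 3 (0.52 log units; beyond the scatter) and so repeats, with a second and quite different acyl group, the modest step that compound 1 alone had shown at this oxygen. Swapping the chain for a ring on the carbonyl carbon gives a 1.0-fold higher number from compound 1 to compound 3 (0.01 log units; within the scatter) and leaves the two esters indistinguishable in this assay, even though one carries an open hexyl chain and the other a six-membered aromatic ring. Across these three compounds, the lower number therefore goes with having an acyl group on this oxygen rather than a free hydrogen, and exchanging hexyl for phenyl on the carbonyl carbon makes no difference that can be read beyond the scatter.

From the compounds shown here alone, it remains open whether a shorter acyl group such as acetyl, a longer chain, or a link of another kind at this oxygen, such as a methyl ether, would give a similar number or move it further. Nothing available here explains why acylating this oxygen goes with a lower number.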